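Inverting one hydroxyl stereocentre on the cyclobutyl ring

This account rests on a few compounds, and the source may have more. Where it says the series, first, only, none or still open, it means among the compounds named here.

Measured compounds:
Compound 1, `N#Cc1cnc(NCc2cncnc2-c2ccccc2)cc1N[C@H]1CC[C@@H](O)CC1`, gives 90 nM in an assay on isolated protein for inhibition of protein kinase C delta type (Homo sapiens), read by TR-FRET, with a stated time of 2 h; on this read-out higher numbers stand for weaker inhibition and lower numbers for stronger inhibition.
Compound 2, `CC1(C)C[C@H](Nc2nc(NCc3cnccc3C(F)(F)F)ncc2C#N)CC[C@@H]1O`, gives 800 nM in this assay.
Compound 3, `CC1(C)[C@@H](O)C[C@H]1Nc1nc(NCc2cnccc2C(F)(F)F)ncc1C#N`, gives 600 nM in this assay.

Compound 3 sits second highest of the three numbers: compound 2 lies closest, a step within the scatter, while compound 1 lies furthest, beyond the scatter. Compound 4, `CC1(C)[C@H](O)C[C@H]1Nc1nc(NCc2cnccc2C(F)(F)F)ncc1C#N`, differs from compound 3 by the two compounds have the same atoms and bonds and differ only in configuration as drawn: 1 of 2 stereo elements differ; a stereocentre at a saturated ring carbon is drawn S in compound 3 and R in compound 4. Going by the values given here, no measured step concerns a change of configuration alone; the only single-point step recorded, a 1.3-fold lower number from compound 2 to compound 3 (0.12 log units; within the scatter), swaps one ring for another and stayed within the scatter. Nothing here argues for a move beyond the scatter, so compound 4 is expected to give about 600 nM, within 250 nM to 1500 nM, an estimated step of no change at the digits printed from compound 3 to compound 4 (within the scatter).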

Compound 4, half-maximal inhibitory concentration: 4500 nM
Estimate against measurement, compound 4: 7.5-fold (0.88 log units) below; the measured number lies above the stated range.
By their numbers in this assay, from the lowest: compound 1; then compounds 3 and 2 (each within the scatter of the next); then compound 4.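

Configuration alone matters at this saturated ring carbon: going from S to R in this assay gives a 7.5-fold higher number from compound 3 to compound 4 (0.88 log units; beyond the scatter). This step can be assigned to that single stereocentre because nothing else separates the pair: the fact that compounds 3 and 4 differ only in the configuration as drawn. The swap from cyclohexyl to cyclobutyl also depends on configuration, since the R form shows a 5.6-fold higher number from compound 2 to compound 4 (0.75 log units; beyond the scatter), whereas the S form stayed within the scatter of compound 2.

Going by these compounds, it remains open whether an amine or methoxy group in place of the hydroxyl would show the same dependence on configuration. On these data alone, the effect of inverting the second stereocentre also remains open.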